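The source may report more compounds than this note shows. Statements on the series, on what has been measured and on what is new or still open speak of the compounds shown alone.

Going by the values given here, compound 1 `CC1(C)N=C(N)N=C(N)N1c1ccc(OCc2ccc(S(=O)(=O)F)cc2)c(Cl)c1` is one of three compounds measured in an assay on isolated protein for inhibition of Dihydrofolate reductase (Mus musculus) (on this read-out lower numbers stand for lower potency and higher numbers for higher potency (the scale is a negative logarithm)), where compound 1 gives 7.58. Among those three numbers compound 1 stands second highest. Compound 2 `CC1(C)N=C(N)N=C(N)N1c1ccc(OCc2ccc(S(=O)(=O)F)cc2Cl)c(Cl)c1` gives 7.44 in this assay, and the step of a number 0.14 log units lower from compound 1 to compound 2 (within the scatter) is within the scatter. Among the compounds with values here, compound 3 `CC1(C)N=C(N)N=C(N)N1c1ccc(OCc2ccc(Cl)c(S(=O)(=O)F)c2)c(Cl)c1` gives 8 in this assay, a number beyond the scatter above that of compound 1; compound 3 differs from compound 1 in more than one place, so no single step is drawn between them.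

The unmeasured compound 4 `CC1(C)N=C(N)N=C(N)N1c1ccc(OCc2ccc(COc3ccc(S(=O)(=O)F)cc3)cc2)c(Cl)c1` differs from compound 1 as follows: a group of 12 heavy atoms (7 carbon, 3 oxygen, 1 fluorine, 1 sulfur; one six-membered aromatic ring of carbon only) in place of a group of 4 heavy atoms (2 oxygen, 1 fluorine, 1 sulfur; no ring), on an aromatic carbon. Within the data shown here, the only step measured so far is the addition of a chloro group, which does not resemble this change, so no measured step bears directly on it. Lacking any guiding step, the expectation for compound 4 is a value near that of compound 1, with no step beyond the scatter: the step of a number 0.18 log units lower from compound 1 to compound 4 (within the scatter) is the estimated change. Compound 4 is therefore estimated at 7.4, with a range from 6.7 to 8.1.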

Compound 4, logarithm of the reciprocal of the active concentration, log(1/C): 6.82
Compound 4: middle estimate off by 0.58 log units, on the high side, within the range that was stated.
By their numbers in this assay, from the lowest: compound 4; then compounds 2 and 1 (each within the scatter of the next); then compound 3.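

Going by these compounds alone, this is the first change in a single place that moves the number beyond the scatter in this assay: replacing the fluorosulfonyl group with the larger group containing a six-membered aromatic ring gives a number 0.76 log units lower from compound 1 to compound 4 (beyond the scatter). The aromatic carbon carrying this group is therefore sensitive to what is placed on it, in a way that the chloro step elsewhere on the same ring did not reveal, although compound 4 still gives a measurable 6.82. Nothing shown here offers an explanation for this step.

On these data alone, it remains open whether the lower number goes with the added ring, the atoms linking it or simply the larger group as a whole. A methoxy group, an amine or a carboxylic acid on the same aromatic carbon could help separate these possibilities.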